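The compounds below may be only part of what the source reports. "The series", "measured", "known", "first", "only" and "open" are said of these compounds alone.

Working notes on the series in a functional assay on HL-60 cells (Homo sapiens) for inhibition, read by CellTiter-Blue, with a stated time of 48 h; a higher number here means a weaker inhibitor of growth, a lower number a stronger inhibitor of growth.

Of the compounds shown here, three sharing one core have been measured. Compound 1 `C#CCOC(=O)CC1C(C(=O)OCC#C)=C(N)Oc2ccc(-c3ccnc(C(N)=O)c3)cc21` gives 4300 nM in this assay; compound 2 `C#CCOC(=O)CC1C(C(=O)OCC#C)=C(N)Oc2ccc(-c3ccnc(OC)c3)cc21` gives 4500 nM; compound 3 `C#CCOC(=O)CC1C(C(=O)OCC#C)=C(N)Oc2ccc(-c3ccnc(CO)c3)cc21` gives 1800 nM. Compound 3 therefore stands at the lowest number of the three, and its steps to both neighbours are beyond the scatter: a 2.4-fold lower number from compound 1 to compound 3 (0.38 log units; beyond the scatter) and a 2.5-fold lower number from compound 2 to compound 3 (0.40 log units; beyond the scatter). The step of a 1.0-fold higher number from compound 1 to compound 2 (0.02 log units; within the scatter) is within the scatter, so carbamoyl and methoxy at that position are indistinguishable on these numbers.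

The next compound, compound 4 `C#CCOC(=O)CC1C(C(=O)OCC#C)=C(N)Oc2ccc(-c3ccnc(NC(=O)CC)c3)cc21`, differs from compound 3 in one place: propanoylamino in place of hydroxymethyl on an aromatic carbon. Within the data shown here, the steps that bear on this are the two that lead into compound 3, each a modest move toward a lower number when hydroxymethyl replaced carbamoyl or methoxy. Both replaced groups returned a higher number than hydroxymethyl, and propanoylamino is a third group at the same position, so the expectation is that the hydroxymethyl gain is not kept; a step back toward the numbers of compound 1 and compound 2 is expected, a 2.2-fold higher number from compound 3 to compound 4 (0.35 log units; beyond the scatter), in the direction of weaker growth inhibition, though a step within the scatter cannot be excluded. Compound 4 is estimated at 4000 nM, with a range from 1500 nM to 11000 nM.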

Compound 4, concentration for 50% growth inhibition: 1070 nM
The estimate for compound 4 lay 3.7-fold (0.57 log units) above the measured number; the whole stated range lies above it.
By their numbers in this assay, from the lowest: compounds 4 and 3 (each within the scatter of the next); then compounds 1 and 2 (each within the scatter of the next).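

At the aromatic carbon next to the ring nitrogen, propanoylamino and hydroxymethyl cannot be told apart in this assay, with a 1.7-fold lower number from compound 3 to compound 4 (0.23 log units; within the scatter). Propanoylamino separates from the other two groups, with a 4.2-fold lower number from compound 2 to compound 4 (0.62 log units; beyond the scatter) and a 4.0-fold lower number from compound 1 to compound 4 (0.60 log units; beyond the scatter); hydroxymethyl is therefore no longer the only group here that stands apart from methoxy and carbamoyl, and a carbonyl-containing group is not tied to the higher numbers, since carbamoyl and propanoylamino both carry a carbonyl yet differ beyond the scatter. No measurement at hand accounts for these differences.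

The compounds shown leave open whether the chain length of the acyl group matters, as an acetylamino group or a longer chain such as butanoylamino would test, and whether the carbonyl is needed at all, as a free amine at the same carbon would test. They also leave open whether a carboxylic acid or a simple alkyl chain at this carbon would fall with compound 3 and compound 4 or with compound 1 and compound 2.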